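Methyl for Fluoro on the Aryl Ring of the Shared Core

The source may report more compounds than this note shows. Statements on the series, on what has been measured and on what is new or still open speak of the compounds shown alone.

Compound 3 `CCCCCCCCCCCCCCCCCCNC(=O)[C@H]1CSC(c2ccc(F)cc2)N1` carries a 4-fluorophenyl group on a saturated ring carbon of the shared core. In a functional assay on DU-145 cells (Homo sapiens) for antiproliferative activity, read by sulforhodamine B assay (a higher number here means a weaker inhibitor, a lower number a stronger inhibitor), compound 3 gives 5700 nM; compound 2 `CCCCCCCCCCCCCCCCCCNC(=O)[C@H]1CSC(c2cccc(O)c2)N1`, bearing 3-hydroxyphenyl, gives 5700 nM, and compound 1 `CCCCCCCCCCCCCCCCCCNC(=O)[C@H]1CSC(c2c[nH]c3ccccc23)N1`, bearing 1H-indol-3-yl, gives 8900 nM. The steps of a 1.6-fold lower number from compound 1 to compound 2 (0.19 log units; within the scatter), a 1.6-fold lower number from compound 1 to compound 3 (0.19 log units; within the scatter) and no change at the digits printed from compound 2 to compound 3 (within the scatter) all lie within the scatter, so the three values stand level. Compound 4 `CCCCCCCCCCCCCCCCCCNC(=O)[C@H]1CSC(c2ccc(C)cc2)N1` differs from compound 3 by methyl in place of fluoro on an aromatic carbon. Going by the values given here, no measured step swaps one small substituent on the aryl ring for another; the three aryl replacements seen so far moved nothing beyond the scatter in this assay. The step of no change at the digits printed from compound 3 to compound 4 (within the scatter) is therefore expected to stay within the scatter. Compound 4 is estimated at 5700 nM, between 2500 nM and 13000 nM.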

Compound 4, half-maximal inhibitory concentration: 10500 nM
Compound 4: middle estimate off by 1.8-fold (0.27 log units), on the low side; low and high end bracket the measured number.
By their numbers in this assay, from the lowest: compounds 2, 3, 1 and 4 (each within the scatter of the next).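

In this assay the exchange of fluoro for methyl gives a 1.8-fold higher number from compound 3 to compound 4 (0.27 log units; within the scatter), so a direct swap of one small substituent for another on the aryl ring stays inside the scatter, as the larger aryl replacements did. The other two new comparisons, a 1.8-fold higher number from compound 2 to compound 4 (0.27 log units; within the scatter) and a 1.2-fold higher number from compound 1 to compound 4 (0.07 log units; within the scatter), also stay within it, which leaves all four aryl groups level in this assay. Nothing available explains this flatness. From the compounds shown here alone, whether an amine or a carboxylic acid on this aryl ring would move the number beyond the scatter remains open.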